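This account rests on a few compounds, and the source may have more. Where it says the series, first, only, none or still open, it means among the compounds named here.

Among the measured compounds shown here, in a functional assay on MDA-MB-231 cells (Homo sapiens) for antiproliferative activity, read by MTT assay, with a stated time of 72 h (a lower number here means a stronger inhibitor, a higher number a weaker inhibitor), compound 1 `NC1=NC2(CCSCC2)N(OCCCOc2ccc(Cl)c(Cl)c2)C(N)=N1` gives 10 nM, the lower of the two numbers measured so far. Compound 2 `NC1=NC2(CCOCC2)N(OCCCOc2ccccc2Cl)C(N)=N1` gives 1430 nM, a higher number by a margin beyond the scatter. For the measured compounds named here, the two compounds differ in more than one place, so no measured step isolates a change in the aryl group.

Compound 3 `NC1=NC2(CCSCC2)N(OCCCOc2ccccc2Br)C(N)=N1` keeps the rest of compound 1 and carries 2-bromophenyl in place of 3,4-dichlorophenyl on an oxygen on a saturated carbon.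

The aryl group of compound 3 looks more like that of compound 2 than that of compound 1, while the core of compound 3 matches that of compound 1. A move toward a higher number in this assay, beyond the scatter, is therefore expected, but one that probably stops short of the full gap between the two measured compounds. Going by the values given here, the expected step is a 20-fold higher number from compound 1 to compound 3 (1.30 log units; beyond the scatter), and with only two measured compounds this estimate is loose. For compound 3 the estimated value is 200 nM, with an expected range from 30 nM to 1200 nM.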

Compound 3, half-maximal inhibitory concentration: 10 nM
Compound 3: middle estimate off by 20-fold (1.30 log units), on the high side; the whole stated range lies above it.
By their numbers in this assay, from the lowest: compounds 1 and 3 (each within the scatter of the next); then compound 2.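

In this assay, among the compounds shown here, placing 2-bromophenyl in place of 3,4-dichlorophenyl on an oxygen on a saturated carbon gives no change at the digits printed from compound 1 to compound 3 (within the scatter), the first reading at this position with everything else held constant. On the core of compound 1, this position therefore accepts a change in both the identity and the placement of the halogen on the phenyl ring without a shift beyond the scatter, so this one exchange does not separate the two aryl groups in this cell assay. Nothing shown gives a measured reason for this flat step.

As far as these compounds go, compound 2 differs from both compound 1 and compound 3 in more than one place, so its higher number cannot yet be assigned to its aryl group, its core or the two together, and whether the same tolerance holds on the core of compound 2 remains open. Also open, from the compounds shown here alone, is how far this tolerance extends beyond halogen-bearing phenyl groups, for example to unsubstituted phenyl, to a phenyl ring carrying an amine or a carboxylic acid, or to a longer chain between the oxygen atoms.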